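Fluorocyclopropyl Amide on a Shared Bicyclic Core

The source may report more compounds than this note shows. Statements on the series, on what has been measured and on what is new or still open speak of the compounds shown alone.

Three amides built on one shared core have been measured in an assay on SH-EP1 cells for agonist activity at Neuronal acetylcholine receptor; alpha4/beta2 (Homo sapiens), read by FLIPR and calcium flux; a lower number here means a smaller maximal response, a higher number a larger maximal response. Compound 1 `CC(C)C(=O)N1CC2CC(C1)N2` gives 86%, the second highest of the three numbers. Compound 3 `O=C(CC1C=CCC1)N1CC2CC(C1)N2` gives 89%, a number that lies within the scatter of compound 1. Compound 2 `O=C(C1CCCC1)N1CC2CC(C1)N2` gives 48%, a number well below compound 1 and beyond the scatter. Compound 4 `O=C([C@@H]1C[C@H]1F)N1CC2CC(C1)N2` has not yet been measured; it differs from compound 1 by 2-fluorocyclopropyl in place of isopropyl on a carbonyl carbon. Going by the values given here, no step between measured compounds that differ in a single place is available, so the expectation rests only on the spread of the three values. A moderate decrease is expected, a number 14 percentage points lower from compound 1 to compound 4 (beyond the scatter), possibly beyond the scatter. Compound 4 is expected to reach 72%, in a range from 45% to 95%.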

Compound 4, largest response reached (Emax), in percent of the reference or control that the assay uses: 110%
For compound 4 the middle estimate is 38 percentage points below the measured one, outside the stated range (above it).
By their numbers in this assay, from the lowest: compound 2; then compounds 1 and 3 (each within the scatter of the next); then compound 4.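

In this assay, going by these compounds alone, the change to 2-fluorocyclopropyl in place of isopropyl on a carbonyl carbon gives a number 24 percentage points higher from compound 1 to compound 4 (beyond the scatter) and is the first single change at this place that can be read. It shows that a fluorinated three-membered ring here is compatible with a high maximal response, with compound 4 at 110% as printed. No supporting measurement bears on why the response changes. The compounds shown leave open whether the step belongs to the ring or to the fluorine, which plain cyclopropyl would separate. As far as these compounds go, the opposite stereoisomer of 2-fluorocyclopropyl also remains open.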